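This account rests on a few compounds, and the source may have more. Where it says the series, first, only, none or still open, it means among the compounds named here.

Measured so far in a functional assay on MDA-MB-231 cells (Homo sapiens) for cytotoxicity, read by MTT assay, with a stated time of 72 h; a lower number here means a stronger inhibitor, a higher number a weaker inhibitor:

Compound 1 `O=C(CN1CCN(c2nnc(Cc3ccncc3)c3ccccc23)CC1)Nc1ccc(F)c(F)c1`: 0.84 nM
Compound 2 `O=C(CN1CCN(c2nnc(Cc3ccccc3)c3ccccc23)CC1)Nc1ccc(F)c(C(F)(F)F)c1`: 760 nM

Of these two numbers, compound 1 has the lowest, and by a wide margin. In this assay compound 2 gives 760 nM, a far higher number than that of compound 1, well beyond the scatter. The two structures differ in more than one place, so this pair alone does not tell which change matters.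

Compound 3 `Cc1ccccc1NC(=O)CN1CCN(c2nnc(Cc3ccncc3)c3ccccc23)CC1` has not yet been measured. It differs from compound 1 in one place only: 2-methylphenyl in place of 3,4-difluorophenyl on an amide-type nitrogen. The group that leaves and the group that enters both sit on the amide-type nitrogen whose other neighbour is the carbonyl carbon, with the shared core unchanged. Among the measured compounds shown here, no measured pair isolates the effect of a change at this nitrogen, so the expectation can rest only on where compound 1 stands.

Compound 1 gives 0.84 nM, a very low number, which leaves far more room for the number to rise than to fall. The step from compound 1 to compound 3 is therefore expected to be a moderate rise, a 9.5-fold higher number from compound 1 to compound 3 (0.98 log units; beyond the scatter), beyond the scatter. Compound 3 is expected to give about 8 nM in this assay, within a range from 1.5 nM to 50 nM.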

Compound 3, half-maximal inhibitory concentration: 200 nM
Compound 3: middle estimate off by 25-fold (1.40 log units), on the low side, and the stated range ends below it.
By their numbers in this assay, from the lowest: compound 1; then compound 3; then compound 2.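

Among the compounds shown here, this is the first pair that isolates a single change on the amide-type nitrogen: in this assay, 2-methylphenyl in place of 3,4-difluorophenyl gives a 240-fold higher number from compound 1 to compound 3 (2.38 log units; beyond the scatter), a large step well beyond the scatter. The group on this nitrogen therefore matters greatly for the read-out: the shared core is unchanged, and both groups are a single six-membered aromatic ring of carbon only, so having such a ring here does not by itself secure the very low number of compound 1. For the compounds shown here, no independent measurement bears on why this swap moves the number so far.

The pair leaves open whether the rise follows from losing the two fluorine atoms, from gaining the methyl group, or from both together, and a plain phenyl group on the same nitrogen would help to separate these possibilities. It also leaves open how far this position tolerates other kinds of group, such as a cyclohexyl ring or a short alkyl chain, and whether the same swap would give a step of similar size on a different core.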